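Chloro in place of nitro on compound 3

The source may report more compounds than this note shows. Statements on the series, on what has been measured and on what is new or still open speak of the compounds shown alone.

In an ADME assay on HEK-293T cells (Homo sapiens) for cytotoxicity, read by MTT assay, with a stated time of 24 h (a lower number here means that less compound is tolerated, a higher number that more compound is tolerated), compound 1 `FC(F)(F)c1ccc(-c2nn(-c3ccccc3)cc2-c2nc3ccccc3[nH]2)cc1` gives 167000 nM while compound 2 `O=S(=O)(c1ccccc1)n1c(-c2cn(-c3ccccc3)nc2-c2ccc(C(F)(F)F)cc2)nc2ccccc21` gives 128000 nM and compound 3 `O=[N+]([O-])c1ccc(S(=O)(=O)n2c(-c3cn(-c4ccccc4)nc3-c3ccc(C(F)(F)F)cc3)nc3ccccc32)cc1` gives 163000 nM so that all three values sit close together. Compound 3 thus stands within the scatter of both other compounds, as a 1.0-fold lower number from compound 1 to compound 3 (0.01 log units; within the scatter) and a 1.3-fold higher number from compound 2 to compound 3 (0.10 log units; within the scatter) show. The remaining step, a 1.3-fold lower number from compound 1 to compound 2 (0.12 log units; within the scatter) and so no larger, completes the picture.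

Compound 4 `O=S(=O)(c1ccc(Cl)cc1)n1c(-c2cn(-c3ccccc3)nc2-c2ccc(C(F)(F)F)cc2)nc2ccccc21` differs from compound 3 by chloro in place of nitro on an aromatic carbon, para to a large group, which turns (4-nitrophenyl)sulfonyl into (4-chlorophenyl)sulfonyl. Going by the values given here, the counted difference is chloro in place of nitro on an aromatic carbon and no measured step makes this exchange directly. The nearest evidence is the step that introduces the nitro, a 1.3-fold higher number from compound 2 to compound 3 (0.10 log units; within the scatter) and it stays small. Adding either sulfonyl group to compound 1 also left the number within the scatter, as a 1.0-fold lower number from compound 1 to compound 3 (0.01 log units; within the scatter) shows. On these three compounds, no change beyond the scatter is expected in this assay for this exchange. The expected step is a 1.1-fold lower number from compound 3 to compound 4 (0.04 log units; within the scatter) and it is not expected to exceed the scatter. For compound 4 the estimated value is 150000 nM with 95000 nM to 235000 nM as the expected range.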

Compound 4, half-maximal cytotoxic concentration: 75300 nM
Compound 4: the middle estimate sits 2.0-fold (0.30 log units) above what was measured; measured number outside the range, below it.
By their numbers in this assay, from the lowest: compounds 4, 2, 3 and 1 (each within the scatter of the next, the first and the last beyond it).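

Going by these compounds alone, at the position para to a large group on the sulfonyl-bearing ring, the exchange of nitro for chloro gives the first single change in this small set to pass the scatter in this assay (a 2.2-fold lower number from compound 3 to compound 4 (0.34 log units; beyond the scatter)), though the step is modest. Chloro in place of hydrogen at the same position does not pass it (a 1.7-fold lower number from compound 2 to compound 4 (0.23 log units; within the scatter)), so only the comparison with the nitro compound, and not the one with the plain phenylsulfonyl compound, separates compound 4 at this position. The full (4-chlorophenyl)sulfonyl group on the aromatic nitrogen of compound 1 also gives a modest step beyond the scatter (a 2.2-fold lower number from compound 1 to compound 4 (0.35 log units; beyond the scatter)), unlike the phenylsulfonyl and (4-nitrophenyl)sulfonyl groups, and nothing in the data shown accounts for this difference.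

The compounds shown leave open whether the chloro result is particular to that atom or extends to bromo, fluoro, methoxy, an amine or a carboxylic acid at this position. They also leave open whether the same exchange would give a similar step on a core other than the one shared here.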